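The source may hold more compounds than are shown below. What is called first, only, known or untested is meant among the compounds shown, and "the series" means these compounds.

Measured compounds:
compound 1, `O=C(CSc1nnnn1-c1cccc2ccccc12)N/N=C/c1cccs1` – > 316000 nM
compound 2, `COc1cccc(/C=N/NC(=O)CSc2nnnn2-c2cccc3ccccc23)c1OC` – 192000 nM

In an ADME assay on MT4 cells (Homo sapiens) for cytotoxicity, read by MTT assay (a lower number here means that less compound is tolerated, a higher number that more compound is tolerated), compound 2 gives 192000 nM, the only number shown for this group. For compound 1 the assay reports only a limit, (the limit of > 316000 nM in this assay, at which 1 of the 2 values shown sits), and no number. Within the data shown here, the one measured step, an at least 1.6-fold lower number from compound 1 to compound 2 (0.21 log units; that floor lies within the scatter), is the step from compound 1 to compound 2, and it is only a floor that lies within the scatter.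

Compound 3, `COc1ccc(/C=N/NC(=O)CSc2nnnn2-c2cccc3ccccc23)cc1OC`, keeps the shared core of compound 2 and differs from it by 3,4-dimethoxyphenyl in place of 2,3-dimethoxyphenyl on a carbon with a double bond to nitrogen. Among the measured compounds shown here, no measured step covers this change; the step from compound 1 to compound 2 swaps a different group and is itself within the scatter. Compound 3 is therefore expected to show no step beyond the scatter, a 1.0-fold higher number from compound 2 to compound 3 (0.02 log units; within the scatter). The estimate for compound 3 in this assay is 200000 nM, with a range from 90000 nM to 420000 nM.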

Compound 3, half-maximal cytotoxic concentration: 191000 nM
For compound 3 the middle estimate is 1.0-fold (0.02 log units) above the measured one, and the stated range covers the measured number.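

Among these compounds, exchanging 2,3-dimethoxyphenyl for 3,4-dimethoxyphenyl on a carbon with a double bond to nitrogen gives the first step in this assay between two actual numbers, and it is a 1.0-fold lower number from compound 2 to compound 3 (0.00 log units; within the scatter). Thus, for these two compounds, the arrangement of the two methoxy groups makes no readable difference. The comparison with thiophen-2-yl gains no sharper reading, since an at least 1.6-fold lower number from compound 1 to compound 3 (0.21 log units; that floor lies within the scatter) is only a floor, and compound 1 remains a limit rather than a number: the limit of > 316000 nM in this assay, at which 1 of the 3 values shown sits.

The compounds shown leave open whether any replacement at this place can bring the number beyond the scatter, since only these two dimethoxyphenyl groups and thiophen-2-yl appear there. A phenyl ring carrying a carboxylic acid or an amine, for instance, is not among them.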